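A few compounds are considered here, and "the series" means these few. Any claim that something is new, unique, unknown or untested is made for them only; others in the source may bear on it.

Compound 2 `CC(C)OC(=O)C(C)ON1C(=O)c2ccccc2C1=O` was tested in a functional assay on the whole organism for inhibition, with Lepidium sativum as the target, tested at 1 ppm (a lower number here means less inhibition of growth, a higher number more inhibition of growth at the concentration tested), where compound 2 gives 51%. This is the highest of the two numbers shown. Among the measured compounds shown here, the other measured compound, compound 1 `CCOC(=O)C(Cc1ccccc1)ON1C(=O)c2ccccc2C1=O`, gives 0% in this assay, a number that lies below the one for compound 2 by more than the scatter; the two structures differ in more than one place, so only their two values can be set side by side.

Compound 3 `CCC(C)OC(=O)C(C)ON1C(=O)c2ccccc2C1=O` has not yet been measured in this assay. It differs from compound 2 by methyl in place of hydrogen on a saturated chain carbon, two bonds along the chain from an oxygen next to a carbonyl group. With no step between measured compounds that differ in just one place, there is nothing in the shown numbers to say in which direction this change moves the growth inhibition, so a step of no more than the scatter is expected, in either direction. The estimate for compound 3 in this assay is 50%, with a range from 20% to 80%, which means an expected step of a number 1 percentage points lower from compound 2 to compound 3 (within the scatter).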

Compound 3, percent growth inhibition at one concentration: 42%
Compound 3: the middle estimate sits 8 percentage points above what was measured, and the stated range covers the measured number.
By their numbers in this assay, from the lowest: compound 1; then compounds 3 and 2 (each within the scatter of the next).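

Going from isopropoxy to sec-butoxy gives a number 9 percentage points lower from compound 2 to compound 3 (within the scatter) in this assay, the first comparison in this set of compounds that differ in only one place. It shows that methyl in place of hydrogen on a saturated chain carbon, two bonds along the chain from an oxygen next to a carbonyl group, causes no change in growth inhibition that can be told apart from the scatter. No measurement at hand bears on the reason for this result.

Going by these compounds, whether a longer chain, such as hexyl, or a benzyl group on the same ester oxygen would also leave the growth inhibition within the scatter remains open. The compounds shown also do not tell which structural difference from compound 2 goes with the value of compound 1, 0%.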